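A few compounds are considered here, and "the series" means these few. Any claim that something is new, unique, unknown or untested is made for them only; others in the source may bear on it.

Measured in a functional assay on HepG2 cells (Homo sapiens) for cytotoxicity, with a stated time of 72 h; a higher number here means that more compound is needed for the effect, a lower number that less compound is needed:

- Compound 1 `C=C[C@@](C)(/C=C/c1ccc(OCc2ccccc2)cc1)CCC=C(C)C`: > 52000 nM
- Compound 2 `C=C[C@@](C)(/C=C/c1ccc(Nc2ccc(F)cc2)cc1)CCC=C(C)C`: > 52000 nM
- Compound 3 `C=C[C@@](C)(/C=C/c1ccc(Nc2ccc(C(F)(F)F)cc2)cc1)CCC=C(C)C`: > 52000 nM

Each of these values is a limit and not a number. Compound 2 therefore has no exact position on the scale, and it stands with the other two compounds at the limit of > 52000 nM in this assay, at which 3 of the 3 values shown sit.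

Compound 4 `C=C[C@@](C)(/C=C/c1ccc(-c2ccccc2)cc1)CCC=C(C)C` differs from compound 2 in one place, with phenyl in place of (4-fluorophenyl)amino on an aromatic carbon, para to a large group: phenyl in place of (4-fluorophenyl)amino on an aromatic carbon.

Within the data shown here, two measured steps bear on this change. The closer one is a step that the two limits leave unreadable from compound 1 to compound 2, since it alters the same substituent. The other is a step that the two limits leave unreadable from compound 2 to compound 3, which alters the outer ring of that substituent. Neither has a readable size, so neither gives a number to carry over to the new step, and neither shows a direction. All three compounds nevertheless ended at the same limit in this assay, so no step beyond the usual scatter is expected, and compound 4 may well report only a limit too.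

The expected change is a step that the limit leaves unreadable from compound 2 to compound 4. Compound 4 is estimated at about 60000 nM, with an expected range from 30000 nM to 100000 nM.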

Compound 4, half-maximal effective concentration: > 52000 nM
Compound 4 gave a limit, no number; the forecaster's own chance of this, stated with the estimate: 85%; the middle value is on the limit's open side.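

In this assay compound 4 gave > 52000 nM, which is a limit and not a number. The steps from compound 1 and compound 2 to compound 4 therefore cannot be read, and the four compounds stand together: the limit of > 52000 nM in this assay, at which 4 of the 4 values shown sit. The compounds shown leave open where the true value of each lies, and so whether exchanging these groups changes the result in this assay at all.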